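The compounds below may be only part of what the source reports. "The series", "measured", "known", "first", "only" and "open" are said of these compounds alone.

Two compounds of a shared core have been examined in a functional assay on the whole organism with Rattus norvegicus as the target (on this read-out lower numbers stand for an effect already at smaller amounts and higher numbers for an effect only at larger amounts of compound), so far. Compound 1, `CCc1c(OC)nc2nc(C(=O)c3ccccc3)cn2c1C`, gives 2 mg/kg in this assay. Compound 2, `CCc1c(OC)nc2nc(C(=O)c3ccccc3)cn2c1CC`, gives 2 mg/kg. The one step between them, no change at the digits printed from compound 1 to compound 2 (within the scatter), lengthens the chain on that carbon without any movement of the read-out, so compound 2 stands level with compound 1 at the digits shown.

Compound 3, `CCc1cn2cc(C(=O)c3ccccc3)nc2nc1OC`, is the next compound to be measured in this assay. Against compound 2 it differs in one place: hydrogen in place of ethyl on an aromatic carbon. Among the compounds with values here, only one measured step bears on this position, the step from compound 1 to compound 2, and it was flat within the scatter. That step added a carbon to the chain, whereas the present change removes the chain altogether, so it is weaker evidence than it first appears. On that basis a small or no step beyond the scatter is expected, a 1.5-fold higher number from compound 2 to compound 3 (0.18 log units; within the scatter), with a wider range to reflect the larger change. Compound 3 is therefore estimated to give 3 mg/kg in this assay, between 1 mg/kg and 8 mg/kg.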

Compound 3, minimum effective dose: 5 mg/kg
Compound 3: middle estimate off by 1.7-fold (0.22 log units), on the low side, within the range that was stated.
By their numbers in this assay, from the lowest: compounds 1 and 2 (each within the scatter of the next); then compound 3.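

In this assay the aromatic carbon next to the ring nitrogen, opposite the position of the flat step between methyl and ethyl in name only, turns out not to be indifferent to losing its group: hydrogen in place of ethyl gives a 2.5-fold higher number from compound 2 to compound 3 (0.40 log units; beyond the scatter) and hydrogen in place of methyl gives a 2.5-fold higher number from compound 1 to compound 3 (0.40 log units; beyond the scatter) in the same direction. The earlier compounds shown here showed only that methyl and ethyl stand level on this carbon, whereas these two steps show that either group goes with a smaller effective dose than hydrogen, modestly but beyond the scatter. The tolerance seen between the two small alkyl groups therefore does not extend to removing the group altogether.

The compounds shown leave open how far this position can be taken in the other direction, whether a longer chain such as propyl would keep the level of methyl and ethyl, and how an amine or a carboxylic acid on this carbon would read out. They also leave open why the number rises when the group leaves, since nothing measured alongside these doses speaks to it.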